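Side-chain carbamate to dimethylamide: outlook for compound 4

The source may hold more compounds than are shown below. What is called first, only, known or untested is meant among the compounds shown, and "the series" means these compounds.

Three compounds of the series have numbers in a functional assay on L1210 cells (Mus musculus), with a stated time of 1 days; on this read-out higher numbers stand for higher potency (the scale is a negative logarithm) and lower numbers for lower potency. Compound 1 `CCCC1=C(N2CC2)C(=O)C(C(COC(N)=O)OC)=C(N2CC2)C1=O` gives 4.64; compound 3 `COCCC1=C(N2CC2)C(=O)C(CCOC)=C(N2CC2)C1=O` gives 4.71; compound 2 `CC1=C(N2CC2)C(=O)C(CCCOC(N)=O)=C(N2CC2)C1=O` gives 5.48, the highest of the three, standing beyond the scatter above both compound 3 and compound 1. Compound 2 thus sets the mark against which compound 4 is to be read.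

Compound 4 `CC1=C(N2CC2)C(=O)C(CCC(=O)N(C)C)=C(N2CC2)C1=O` has not yet been measured in this assay. Its structure differs from compound 2 in one place: dimethylcarbamoyl in place of (carbamoyloxy)methyl on a saturated chain carbon, two bonds along the chain from a double-bonded ring carbon. The hydrogen-bond donor of the (carbamoyloxy)methyl group is lost with the change, and the carbamate oxygen is gone as well, while a dimethylcarbamoyl group of the same heavy-atom count takes its place.

Within the data shown here, no step between measured compounds of one difference is available to calibrate this change. Compound 3, which carries no carbamate on either chain, gives 4.71, and compound 1 with a carbamate on a different chain gives 4.64, so the carbamate alone does not settle the number. Compound 4 is expected to fall below compound 2 by a step of a number 0.58 log units lower from compound 2 to compound 4 (beyond the scatter), a drop beyond the scatter. The estimate for compound 4 in this assay is 4.9, with a range from 4.3 to 5.5.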

Compound 4, logarithm of the reciprocal of the active concentration, log(1/C): 4.84
Compound 4: middle estimate off by 0.06 log units, on the high side, and the stated range covers the measured number.
By their numbers in this assay, from the lowest: compounds 1, 3 and 4 (each within the scatter of the next); then compound 2.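

In this assay, among these compounds, dimethylcarbamoyl in place of (carbamoyloxy)methyl on a saturated chain carbon, two bonds along the chain from a double-bonded ring carbon, gives a number 0.64 log units lower from compound 2 to compound 4 (beyond the scatter); this is the first one-place step and shows that the number responds to the group at this position. The heavy-atom count is the same on both sides, so this step comes with a change in the kind of atoms and in the donor and acceptor counts, with no change in heavy-atom number, and a single step cannot separate these differences. No measurement on hand explains the step.

As far as these compounds go, whether the loss of the hydrogen-bond donor or the loss of the carbamate oxygen carries the step remains open: an unsubstituted carbamoyl or a methylcarbamoyl group at the same place would keep the amide hydrogen without the carbamate oxygen. From the compounds shown here alone, how far this position tolerates other kinds of group also remains open, and a carboxylic acid, an amine or a longer carbamate chain there would bear on that question.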